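The compounds below may be only part of what the source reports. "The series", "measured", "known", "first", "only" and "open" are said of these compounds alone.

Compound 2 `Cc1cc(C)c(Oc2cc(Nc3ccc(C#N)cc3)ncc2C(=O)NCc2cn(Cc3cccc(C#N)c3)nn2)c(C)c1` is tested in an ADME assay on MT4 cells (Homo sapiens) for cytotoxicity, read by MTT assay, with a stated time of 5 days; a higher number here means that more compound is tolerated, a lower number that less compound is tolerated. In this assay compound 2 reaches only the limit of the measurement, >= 129000 nM, so no exact number is known. Compound 1 `Cc1cc(C)c(Oc2cc(Nc3ccc(C#N)cc3)ncc2C(=O)NCc2cn(Cc3ccccc3Cl)nn2)c(C)c1` likewise stops at a limit, giving >= 188000 nM in this assay. Within the data shown here, the only measured step, a step that the two limits leave unreadable from compound 1 to compound 2, therefore has no readable size, since both values sit at limits (the limit of >= 129000 nM in this assay, at which 1 of the 2 values shown sits, and (the limit of >= 188000 nM in this assay, at which 1 of the 2 values shown sits)). Compound 3 `Cc1cc(C)c(Oc2cc(Nc3ccc(C#N)cc3)ncc2C(=O)NCc2cn(CC(=O)N3CCOCC3)nn2)c(C)c1` differs from compound 2 by (morpholin-4-yl)carbonyl in place of 3-cyanophenyl on a saturated chain carbon bound to an aromatic nitrogen. With no readable step to lean on, compound 3 is expected to move little, a step that the limit leaves unreadable from compound 2 to compound 3, and will most likely stop at a limit again. Compound 3 is estimated at 150000 nM, within 60000 nM to 350000 nM.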

Compound 3, half-maximal cytotoxic concentration: 181000 nM
Compound 3: the middle estimate sits 1.2-fold (0.08 log units) below what was measured; the measured number falls inside the stated range.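

In this assay, compound 3 gives the only exact number among the compounds shown, so this place now has one firm value, carried by a group with no aromatic ring. Exchanging 2-chlorophenyl for (morpholin-4-yl)carbonyl gives an at least 1.0-fold lower number from compound 1 to compound 3 (0.01 log units; that floor lies within the scatter). The step from compound 2 to compound 3 cannot be read because compound 2 holds only a limit: the limit of >= 129000 nM in this assay, at which 1 of the 3 values shown sits.

Still open, as far as these compounds go, is whether an amine, a carboxylic acid or a longer chain on this saturated chain carbon would bring the number clearly down.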